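Losing the Ethoxy Group from Compound 3

The compounds below may be only part of what the source reports. "The series", "measured", "known", "first", "only" and "open" are said of these compounds alone.

In an ADME assay on Vero cells (Chlorocebus sabaeus) for cytotoxicity, read by MTT assay, with a stated time of 72 h (on this read-out lower numbers stand for higher toxicity in this test and higher numbers for lower toxicity in this test), compound 1 `COc1ccc(/C=C/c2cc(SC)nc(N)n2)cc1` gives 250000 nM, compound 2 `CSc1cc(/C=C/c2ccc(OCc3ccccc3)cc2)nc(N)n1` gives 376000 nM and compound 3 `CCOc1cc(/C=C/c2cc(SC)nc(N)n2)ccc1OC1CCCCO1` gives 248000 nM. These three values all lie within the scatter of one another, so compound 3 holds no distinct place among them. Compound 4 `CSc1cc(/C=C/c2ccc(OC3CCCCO3)cc2)nc(N)n1` differs from compound 3 by hydrogen in place of ethoxy on an aromatic carbon, ortho to a (oxan-2-yl)oxy group (hydrogen in place of ethoxy on an aromatic carbon). For the measured compounds named here, no measured step removes ethoxy, so the evidence is indirect. Going by the values given here, the one measured step, a 1.5-fold higher number from compound 1 to compound 2 (0.18 log units; within the scatter), places phenyl on a saturated chain carbon bound to an oxygen on an aromatic ring, and even that addition stays within the scatter. With so little movement in this assay across the series, no shift beyond the scatter is expected here. The expected step is a 1.1-fold higher number from compound 3 to compound 4 (0.04 log units; within the scatter), which is no real change. For compound 4 the estimated value is 270000 nM, with an expected range of 140000 nM to 500000 nM.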

Compound 4, half-maximal cytotoxic concentration: 122000 nM
Beside the measured number, compound 4's estimate is 2.2-fold (0.35 log units) above it, and the stated range ends above it.
By their numbers in this assay, from the lowest: compound 4; then compounds 3, 1 and 2 (each within the scatter of the next).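

In this assay, for the compounds shown here, the step of a 2.0-fold lower number from compound 3 to compound 4 (0.31 log units; beyond the scatter) is beyond the scatter, unlike the one earlier step, so the group on this aromatic carbon, ortho to a (oxan-2-yl)oxy group, does register: with hydrogen in place of ethoxy the number falls. The group on the oxygen registers too once ethoxy is gone, with oxan-2-yl in place of methyl giving a 2.0-fold lower number from compound 1 to compound 4 (0.31 log units; beyond the scatter) and oxan-2-yl in place of benzyl giving a 3.1-fold lower number from compound 2 to compound 4 (0.49 log units; beyond the scatter), which leaves compound 4 with the lowest number of the four. Nothing measured here explains either shift.

The compounds shown carry only ethoxy or hydrogen on this carbon, so it remains open how methoxy, a longer alkoxy chain or an amine there would read. As far as these compounds go, it also remains open whether ethoxy would have the same effect with methyl or benzyl on the oxygen.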